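Series notes: arm replacement from compound 3 to compound 4

This account rests on a few compounds, and the source may have more. Where it says the series, first, only, none or still open, it means among the compounds named here.

Three analogues sharing one core have been run in a functional assay on HeLa cells (Homo sapiens) for cytotoxicity, read by MTT assay, with a stated time of 72 h; a higher number here means a weaker inhibitor, a lower number a stronger inhibitor. Compound 1 `CN1CCN(Cc2nnc(-c3cc(S(N)(=O)=O)c(SCc4ccccc4)cc3Cl)o2)CC1` gives 75000 nM; compound 2 `CC(C)(O)c1cn(Cc2nnc(-c3cc(S(N)(=O)=O)c(SCc4ccccc4)cc3Cl)o2)nn1` gives 68000 nM; compound 3 `NS(=O)(=O)c1cc(-c2nnc(CNS(=O)(=O)c3ccc(Cl)cc3)o2)c(Cl)cc1SCc1ccccc1` gives 24000 nM. The change a 1.1-fold lower number from compound 1 to compound 2 (0.04 log units; within the scatter) is within the scatter, whereas a 3.1-fold lower number from compound 1 to compound 3 (0.49 log units; beyond the scatter) and a 2.8-fold lower number from compound 2 to compound 3 (0.45 log units; beyond the scatter) are beyond it, so compound 3 holds the lowest number of the three. Compound 4 `NS(=O)(=O)c1cc(-c2nnc(/C=C/c3ccc(Cl)cc3)o2)c(Cl)cc1SCc1ccccc1` differs from compound 3 by 2-(4-chlorophenyl)ethenyl in place of (((4-chlorophenyl)sulfonyl)amino)methyl on an aromatic carbon. Going by the values given here, no measured step swaps this exact group; the steps from compound 1 and compound 2 to compound 3 vary the same arm and moved the number only modestly, so in this assay a step of comparable size at most, in either direction, is expected, a 1.2-fold lower number from compound 3 to compound 4 (0.08 log units; within the scatter). Compound 4 is expected to give 20000 nM, between 7000 nM and 60000 nM.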

Compound 4, half-maximal inhibitory concentration: 40000 nM
Compound 4: middle estimate off by 2.0-fold (0.30 log units), on the low side, within the range that was stated.
By their numbers in this assay, from the lowest: compounds 3, 4, 2 and 1 (each within the scatter of the next, the first and the last beyond it).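

In this assay, 2-(4-chlorophenyl)ethenyl, with no hydrogen-bond donors or acceptors, stays within the scatter of all three earlier arms: a 1.7-fold higher number from compound 3 to compound 4 (0.22 log units; within the scatter), a 1.7-fold lower number from compound 2 to compound 4 (0.23 log units; within the scatter) and a 1.9-fold lower number from compound 1 to compound 4 (0.27 log units; within the scatter). At this position, then, losing the donor and acceptors of (((4-chlorophenyl)sulfonyl)amino)methyl produces no step beyond the scatter. No available evidence bears on this result. Open, going by these compounds, is whether a carboxylic acid or a primary amine on this aromatic carbon, or a longer chain in place of the ethenyl link, would move the number beyond the scatter.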